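Methyl Pattern on the Phenyl Ring and Cell Tolerance

The compounds below may be only part of what the source reports. "The series", "measured", "known", "first", "only" and "open" are said of these compounds alone.

Compound 1 `Cc1oc(-c2ccc(Cl)c(Cl)c2)nc1CN1CCC(C(=O)NCCCN2C[C@H](C)C[C@H](C)C2)CC1`: 3170 nM
Compound 2 `Cc1ccc(-c2nc(CN3CCC(C(=O)NCCCN4C[C@H](C)C[C@H](C)C4)CC3)c(C)o2)cc1`: 4330 nM

In an ADME assay on Huh7.5.1 cells (Homo sapiens) for cytotoxicity, read by ATP content, with a stated time of 48 h (a higher number here means that more compound is tolerated, a lower number that less compound is tolerated), compound 2 holds the higher of the two numbers, yet its step from compound 1, a 1.4-fold higher number from compound 1 to compound 2 (0.14 log units; within the scatter), lies within the scatter, so the two compounds cannot be ranked. Compound 3 `Cc1cc(C)cc(-c2nc(CN3CCC(C(=O)NCCCN4C[C@H](C)C[C@H](C)C4)CC3)c(C)o2)c1` differs from compound 2 by 3,5-dimethylphenyl in place of 4-methylphenyl on an aromatic carbon. Going by the values given here, the only measured step touching the same aromatic carbon, a 1.4-fold higher number from compound 1 to compound 2 (0.14 log units; within the scatter), was within the scatter, so no step beyond the scatter is expected here. The expected step is a 1.1-fold lower number from compound 2 to compound 3 (0.03 log units; within the scatter). Compound 3 is estimated at 4000 nM, with a range from 2000 nM to 8500 nM.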

Compound 3, half-maximal cytotoxic concentration: 4050 nM
Estimate against measurement, compound 3: 1.0-fold (0.01 log units) below; measured number inside the range.
By their numbers in this assay, from the lowest: compounds 1, 3 and 2 (each within the scatter of the next).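

Placing 3,5-dimethylphenyl on this aromatic carbon gives a 1.1-fold lower number from compound 2 to compound 3 (0.03 log units; within the scatter) against 4-methylphenyl and a 1.3-fold higher number from compound 1 to compound 3 (0.11 log units; within the scatter) against 3,4-dichlorophenyl. A third substitution pattern on the phenyl ring thus also yields no step beyond the scatter, and the three compounds cannot be ranked in this assay at this position. Nothing at hand offers an explanation for this reading. As far as these compounds go, whether an amine or a carboxylic acid on the phenyl ring would move the number beyond the scatter remains open.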